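Swapping the aryl for a small alkyl on the shared core

The source may hold more compounds than are shown below. What is called first, only, known or untested is meant among the compounds shown, and "the series" means these compounds.

Among the compounds with values here, the series so far holds two measured compounds sharing one core. Compound 1 `CCn1c(CN2CCN(C(=O)C3CC3)CC2)nc2ccccc21` carries methyl on a saturated chain carbon bound to an aromatic nitrogen; in an assay on isolated protein for inhibition of aldehyde dehydrogenase 1A1 (Homo sapiens), read by spectrophotometry, tested at 10 uM (on this read-out higher numbers stand for more inhibition at the one concentration tested (going by the name of the read-out) and lower numbers for less inhibition), compound 1 gives 20.8%. Compound 2 `COc1cccc(Cn2c(CN3CCN(C(=O)C4CC4)CC3)nc3ccccc32)c1` carries 3-methoxyphenyl at the same place and in this assay compound 2 gives 44.4%, the higher of the two numbers, the step of a number 23.6 percentage points higher from compound 1 to compound 2 (beyond the scatter) lying beyond the scatter.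

The next compound is compound 3 `CC(C)Cn1c(CN2CCN(C(=O)C3CC3)CC2)nc2ccccc21`. The change from compound 2 is isopropyl in place of 3-methoxyphenyl on a saturated chain carbon bound to an aromatic nitrogen.

Within the data shown here, only one measured step bears on this: a number 23.6 percentage points higher from compound 1 to compound 2 (beyond the scatter), where the 3-methoxyphenyl replaced methyl. Compound 3 undoes that replacement in part, since isopropyl is again a chain group without a ring, though larger than methyl. A drop in this assay is therefore expected, smaller than the full gain from compound 1 to compound 2 because a number 23.6 percentage points higher from compound 1 to compound 2 (beyond the scatter) compares against methyl rather than isopropyl. The expected step is a number 16.4 percentage points lower from compound 2 to compound 3 (beyond the scatter). Compound 3 is estimated at 28%, within 12% to 45%.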

Compound 3, a percentage reported as inhibition, at one concentration (the size of the read-out at that concentration, not a potency): 13.1%
Compound 3: the middle estimate sits 14.9 percentage points above what was measured; measured number inside the range.
By their numbers in this assay, from the lowest: compounds 3 and 1 (each within the scatter of the next); then compound 2.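

In this assay the step of a number 31.3 percentage points lower from compound 2 to compound 3 (beyond the scatter) shows that the higher number of compound 2 does not carry over to isopropyl, a chain group without a ring that is larger than methyl, at this place on a saturated chain carbon bound to an aromatic nitrogen. The step of a number 7.7 percentage points lower from compound 1 to compound 3 (within the scatter) shows that exchanging methyl for isopropyl gives no readable change, so among these three compounds only compound 2, with its 3-methoxyphenyl, stands apart, while compound 1 and compound 3 cannot be told apart. No independent measurement in hand bears on the reason for this difference at this place.

From the compounds shown here alone, it remains open whether the higher number goes with the aromatic ring itself or with the methoxy group on it, a question that unsubstituted phenyl and cyclohexyl at the same place would help to separate. Going by these compounds, it also remains open whether a longer chain such as hexyl would stay with compound 1 and compound 3 or move toward compound 2.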